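The source may report more compounds than this note shows. Statements on the series, on what has been measured and on what is new or still open speak of the compounds shown alone.

Measured in an in vitro ADME assay on microsomes from liver (Homo sapiens) for metabolic stability, tested at 5 uM (a lower number here means that the compound disappears faster, a higher number that the compound lasts longer), each entry a limit of the assay and not a number:
- compound 1 `CS(=O)(=O)Nc1ccc2c(c1)S(=O)(=O)N=C(c1c(O)c(-c3cccs3)nn(CCC3CC3)c1=O)N2`: > 1 h
- compound 2 `COC(C)(C)CCn1nc(-c2cccs2)c(O)c(C2=NS(=O)(=O)c3cc(NS(C)(=O)=O)ccc3N2)c1=O`: > 1 h
- compound 3 `CS(=O)(=O)Nc1ccc2c(c1)S(=O)(=O)N=C(c1c(O)c(-c3cccs3)nn(CC3CC3)c1=O)N2`: > 1 h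

Compound 3 has only a limit, > 1 h, and no number. The whole set sits at that limit: the limit of > 1 h in this assay, at which 3 of the 3 values shown sit.

Compound 4 `CS(=O)(=O)Nc1ccc2c(c1)S(=O)(=O)N=C(c1c(O)c(-c3cccs3)nn(CCC3CCCCC3)c1=O)N2` carries cyclohexylmethyl in place of cyclopropyl on a saturated chain carbon bound to an aromatic nitrogen.

The measured steps that bear on this change vary the same chain: a step that the two limits leave unreadable from compound 1 to compound 3, a step that the two limits leave unreadable from compound 2 to compound 3 and a step that the two limits leave unreadable from compound 1 to compound 2. None of them has a readable size, so none gives a size or direction to carry over. Among the compounds with values here, the larger cyclohexylmethyl group has no measured precedent here, so the expectation is uncertain.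

The estimated step is a number no higher from compound 3 to compound 4 (the limit leaves the size open), expected in neither direction beyond the scatter. In this assay, another limit is also expected to be a likely outcome. For compound 4 the estimated half-life is 1 h, with an expected range of 0.5 h to 2 h.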

Compound 4, half-life: > 1 h
Compound 4 was reported as a limit (the forecaster's own chance of this, stated with the estimate: 60%); the middle value sits exactly at the limit.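

In this assay compound 4 gives > 1 h, a limit and not a number. No step from compound 1, compound 2 or compound 3 to compound 4 can be read, and the whole set sits at one limit: the limit of > 1 h in this assay, at which 4 of the 4 values shown sit.

The compounds shown leave open whether the chain on the aromatic nitrogen changes the half-life at all.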